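Indane aryl substitution in the melanin-concentrating hormone receptor series

The source may hold more compounds than are shown below. What is called first, only, known or untested is meant among the compounds shown, and "the series" means these compounds.

Measured compounds:
compound 1 `CO[C@@H]1CN(CC2Cc3ccccc3C2)CC[C@H]1n1c(C)nc2cc(C)ccc21` — 47 nM
compound 2 `CO[C@@H]1CN(C[C@@H]2Cc3ccc(NC(=O)C(C)C)cc3C2)CC[C@H]1n1c(C)nc2cc(C)ccc21` — 31 nM

The read-out throughout is an assay on isolated protein for binding affinity to melanin-concentrating hormone receptor 1 (Homo sapiens); on this read-out lower numbers stand for stronger inhibition and higher numbers for weaker inhibition. Compound 1 `CO[C@@H]1CN(CC2Cc3ccccc3C2)CC[C@H]1n1c(C)nc2cc(C)ccc21` gives 47 nM and has the higher of the two numbers recorded; the nearest is compound 2, and the step of a 1.5-fold lower number from compound 1 to compound 2 (0.18 log units; within the scatter) lies within the scatter, so the two cannot be separated in this assay.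

Compound 3 `CO[C@@H]1CN(C[C@H]2Cc3ccc(Br)cc3C2)CC[C@H]1n1c(C)nc2cc(C)ccc21` has not been measured. It differs from compound 1 by bromo in place of hydrogen on an aromatic carbon. Among the measured compounds shown here, the only measured step that bears on this is the one from compound 1 to compound 2, where a different group, (isopropylcarbonyl)amino, also enters on an aromatic carbon of the shared core and changes the number only within the scatter. For the measured compounds named here, no measured pair shows a bromo substituent, so nothing beyond that single step is known about how compound 3 should behave.

On this basis, compound 3 is expected to come out near compound 1, with a step of about a 1.2-fold lower number from compound 1 to compound 3 (0.09 log units; within the scatter), not clearly beyond the scatter in either direction. The estimate for compound 3 in this assay is 38 nM, with a range from 15 nM to 95 nM.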

Compound 3, inhibition constant: 5 nM
Estimate against measurement, compound 3: 7.6-fold (0.88 log units) above; measured number below the stated range.
By their numbers in this assay, from the lowest: compound 3; then compounds 2 and 1 (each within the scatter of the next).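

In this assay, the entry of bromo gives a 9.4-fold lower number from compound 1 to compound 3 (0.97 log units; beyond the scatter), so this aromatic carbon, meta to a fused ring and para to a fused ring, can carry a substituent with a clear gain in the number rather than the flat response seen so far. That flat response came from (isopropylcarbonyl)amino on an aromatic carbon of the shared core, which gave only a 1.5-fold lower number from compound 1 to compound 2 (0.18 log units; within the scatter), so across these two steps the outcome depends on which group enters and not simply on whether the hydrogen is replaced. Nothing in the available data accounts for the size of the bromo step.

As far as these compounds go, whether the gain belongs to bromo alone or extends to chloro, iodo, methyl or methoxy on this carbon remains open, as does the effect of bromo on the other aromatic carbons of this ring. Also open, from the compounds shown here alone, is where a free amine or a shorter acetylamino group would fall on this read-out, given the wide gap between the bromo and (isopropylcarbonyl)amino results.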